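The source may report more compounds than this note shows. Statements on the series, on what has been measured and on what is new or still open speak of the compounds shown alone.

Measured so far in an ADME assay on the whole organism with Oryza sativa as the target, tested at 10 uM; a lower number here means a stronger effect, a higher number a weaker effect of the compound at the concentration tested:
compound 1, `C[C@@H](NC(=O)Nc1ccc(C(C)(C)C)cc1)c1ccccc1`: 53%
compound 2, `C[C@H](NC(=O)Nc1ccc(C(C)(C)C)cc1)c1ccccc1`: 64%
compound 3, `C[C@@H](NC(=O)Nc1cccc(C(F)(F)F)c1)c1ccccc1`: 70%

Compound 2 stands apart from compound 1 and close to compound 3. The step of a number 11 percentage points higher from compound 1 to compound 2 (beyond the scatter) lies beyond the scatter, and it rests on nothing but (the fact that compounds 1 and 2 differ only in the configuration as drawn). For the measured compounds named here, compound 3, with its trifluoromethyl group, gives a value that is within the scatter of the one compound 2 gives, so the two cannot be told apart in this assay.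

Compound 4, `CC(=O)c1ccc(NC(=O)N[C@@H](C)c2ccccc2)cc1`, is the next compound to be measured. It differs from compound 2 in one place: acetyl in place of tert-butyl on an aromatic carbon. Going by the values given here, none of the measured steps bears on this change. Among the compounds with values here, the only step between two measured compounds, from compound 1 to compound 2, alters configuration and not a substituent, and compound 3 carries a different group at a different place with no single-point step to compound 2. There is therefore nothing in the data that points to a direction for the acetyl in place of tert-butyl, and the expectation is a step of no size beyond the scatter, no change at the digits printed from compound 2 to compound 4 (within the scatter). Compound 4 is accordingly estimated at 64% in this assay, within a range from 45% to 85%.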

Compound 4, a percentage reported as activity, at one concentration (the size of the read-out at that concentration, not a potency): 96%
The estimate for compound 4 lay 32 percentage points below the measured number, outside the stated range (above it).
By their numbers in this assay, from the lowest: compound 1; then compounds 2 and 3 (each within the scatter of the next); then compound 4.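

In this assay, the group on this aromatic carbon proves to matter, since acetyl in place of tert-butyl gives a number 32 percentage points higher from compound 2 to compound 4 (beyond the scatter), a large step and one towards a weaker effect at the concentration tested. For the compounds shown here, until now the only step between compounds differing in one place was the modest one of configuration, a number 11 percentage points higher from compound 1 to compound 2 (beyond the scatter), so this is the first sign that a substituent at this place can move the number, and by a wide margin. The entering acetyl brings a hydrogen-bond acceptor and a double bond outside aromatic rings, which the leaving tert-butyl lacks, but nothing measured here accounts for the step or ties it to either feature.

Going by these compounds, with only tert-butyl and acetyl compared at this place, it remains open whether the number rises with the arrival of the carbonyl or with the departure of tert-butyl. An isopropyl group or a methoxy group on the same aromatic carbon could help separate the two readings, and whether the step holds with the configuration of compound 1 is also unsettled.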